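Replacing the Ester Arm: What Compound 4 Might Give

A few compounds are considered here, and "the series" means these few. Any claim that something is new, unique, unknown or untested is made for them only; others in the source may bear on it.

Compound 1 `COC(=O)C(Cc1cccc(OCC(=O)O)c1)c1nc(-c2ccccc2)c(-c2ccccc2)o1` stands as the strongest of the three compounds measured in a functional assay for inhibition, with Homo sapiens as the target (a higher number here means a weaker inhibitor, a lower number a stronger inhibitor), where compound 1 gives 80 nM. Compound 2 `CS(=O)(=O)C(Cc1cccc(OCC(=O)O)c1)c1nc(-c2ccccc2)c(-c2ccccc2)o1` gives 7960 nM, and compound 3 `O=C(O)COc1cccc(CC(c2ccsc2)c2nc(-c3ccccc3)c(-c3ccccc3)o2)c1` gives 20700 nM. The two steps away from compound 1 are both large: a 100-fold higher number from compound 1 to compound 2 (2.00 log units; beyond the scatter) and a 260-fold higher number from compound 1 to compound 3 (2.41 log units; beyond the scatter). Between the two weaker compounds the gap is smaller, a 2.6-fold higher number from compound 2 to compound 3 (0.42 log units; beyond the scatter).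

Compound 4 `C=CCC(Cc1cccc(OCC(=O)O)c1)c1nc(-c2ccccc2)c(-c2ccccc2)o1` differs from compound 1 in one place: allyl in place of methoxycarbonyl on a saturated chain carbon bound to an aromatic carbon and a saturated chain carbon. Both measured exchanges of the methoxycarbonyl at this saturated chain carbon, to methylsulfonyl and to thiophen-3-yl, brought large losses, and nothing measured here shows any replacement of that group holding the potency of compound 1. A large loss is therefore expected for compound 4 as well, in the same direction as a 100-fold higher number from compound 1 to compound 2 (2.00 log units; beyond the scatter). Compound 4 is expected to give 8000 nM, within a range from 1500 nM to 40000 nM. The expected step is a 100-fold higher number from compound 1 to compound 4 (2.00 log units; beyond the scatter).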

Compound 4, half-maximal inhibitory concentration: 570 nM
The estimate for compound 4 lay 14-fold (1.15 log units) above the measured number, and the stated range ends above it.
By their numbers in this assay, from the lowest: compound 1; then compound 4; then compound 2; then compound 3.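

In this assay, this position proves more tolerant than the two earlier exchanges suggested: allyl on this saturated chain carbon costs far less, with a 7.1-fold higher number from compound 1 to compound 4 (0.85 log units; beyond the scatter), so the large losses are not the fate of every replacement of methoxycarbonyl. Allyl also stands clearly ahead of the other two replacements, with a 14-fold lower number from compound 2 to compound 4 (1.15 log units; beyond the scatter) and a 36-fold lower number from compound 3 to compound 4 (1.56 log units; beyond the scatter), and it reaches this with no hydrogen-bond acceptor of its own, though compound 1, whose methoxycarbonyl has two, still gives the lower number. Nothing available explains why allyl fares better than methylsulfonyl or thiophen-3-yl.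

The compounds shown leave open whether the double bond of allyl matters, which a propyl group would test. They also leave open whether a longer chain, an amide or a nitrile at this carbon would match compound 1.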